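The source may report more compounds than this note shows. Statements on the series, on what has been measured and on what is new or still open speak of the compounds shown alone.

Working notes on the series, values in a functional assay on CAL-27 cells (Homo sapiens) for cytotoxicity, read by MTT assay, with a stated time of 72 h; a lower number here means a stronger inhibitor, a higher number a weaker inhibitor:

- compound 1 `Cc1cc(C)cc(C(=O)N(CCCCCC(=O)Nc2ccccc2N)CC(=O)NC2CCCCC2)c1`: 17500 nM
- compound 2 `Cc1ccc(CNC(=O)CN(CCCCCC(=O)Nc2ccccc2N)C(=O)c2cc(C)cc(C)c2)cc1`: 18200 nM
- compound 3 `COc1ccc(CNC(=O)CN(CCCCCC(=O)Nc2ccccc2N)C(=O)c2cc(C)cc(C)c2)cc1`: not yet measured

Compound 2 stands level with compound 1 on these numbers, the only two available, and the gap between them lies within the scatter. The next step keeps the shared core and alters only the 4-methylbenzyl group of compound 2, which becomes 4-methoxybenzyl in compound 3: methoxy in place of methyl on an aromatic carbon. This places methoxy in place of methyl on an aromatic carbon, para to a large group.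

Among the measured compounds shown here, one measured step bears on this change, and only indirectly. It is a 1.0-fold higher number from compound 1 to compound 2 (0.02 log units; within the scatter), where 4-methylbenzyl replaced cyclohexyl on an amide-type nitrogen. Even that larger exchange at the same group left this assay unmoved beyond the scatter. For the measured compounds named here, no measured pair covers methyl and methoxy directly, so the basis is thin. No shift beyond the scatter is expected, and no direction is favoured. The estimated change is a 1.1-fold lower number from compound 2 to compound 3 (0.03 log units; within the scatter). For compound 3 the expected value is 17000 nM, with an estimated range of 8500 nM to 34000 nM.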

Compound 3, half-maximal inhibitory concentration: 17400 nM
The estimate for compound 3 lay 1.0-fold (0.01 log units) below the measured number, and the stated range covers the measured number.
By their numbers in this assay, from the lowest: compounds 3, 1 and 2 (each within the scatter of the next).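

In this assay, among the compounds shown here, the methyl-to-methoxy exchange on an aromatic carbon, para to a large group, gives the first direct reading of this change: a 1.0-fold lower number from compound 2 to compound 3 (0.02 log units; within the scatter). The added oxygen, counted as one hydrogen-bond acceptor, therefore brings no shift beyond the scatter between this pair. The wider exchange of cyclohexyl for 4-methoxybenzyl on the amide-type nitrogen reads a 1.0-fold lower number from compound 1 to compound 3 (0.00 log units; within the scatter), so cyclohexyl, 4-methylbenzyl and 4-methoxybenzyl all stand level in this assay, and no independent measurement is available to explain that flat reading.

Open is whether an amine or a carboxylic acid in place of the methoxy group would depart from this level, since the three compounds shown carry only neutral, carbon-rich groups or a methoxy group at this place. Also open, as far as these compounds go, is whether the same flat reading would hold with any change to the shared core, which stays constant across compounds 1, 2 and 3 and so cannot be separated from the level seen here.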